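The source may hold more compounds than are shown below. What is called first, only, known or untested is meant among the compounds shown, and "the series" means these compounds.

Measured compounds:
- compound 1 `c1ccc2c(c1)CCN(CCCCC1CCCc3ccccc31)C2`: 3.7 nM
- compound 2 `C1=C(CCCCN2CCCCC2)c2ccccc2CC1`: 3.9 nM

In an assay on isolated protein for binding affinity to Adrenergic receptor alpha-1 (Rattus norvegicus), read by radioligand binding (on this read-out higher numbers stand for weaker inhibition and lower numbers for stronger inhibition), compound 2 gives 3.9 nM. Among the compounds with values here, compound 1 gives 3.7 nM in this assay, and the two numbers lie within the scatter of each other, so compound 2 stands alongside compound 1 rather than apart from it; with only two compounds measured, the numbers give no ordering at all.

Compound 3 `CCCN(CCC)CCCCC1=CCCc2ccccc21` is not yet measured. It differs from compound 2 in one place: dipropylamino in place of piperidin-1-yl on a saturated chain carbon, four bonds along the chain from a double-bonded ring carbon. No measured pair isolates this change, so its size is unknown from the data shown. The step of a 2.1-fold higher number from compound 2 to compound 3 (0.31 log units; beyond the scatter) that is expected here is a modest one toward a weaker number, at the edge of the scatter, because compound 2 sits at 3.9 nM and nothing in the two measured values points to a large move in either direction. Compound 3 is therefore estimated at 8 nM, with a range from 2 nM to 30 nM.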

Compound 3, inhibition constant: 3.9 nM
The estimate for compound 3 lay 2.1-fold (0.31 log units) above the measured number; the measured number falls inside the stated range.
By their numbers in this assay, from the lowest: compounds 1, 2 and 3 (each within the scatter of the next).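

In this assay, putting dipropylamino in place of piperidin-1-yl on a saturated chain carbon, four bonds along the chain from a double-bonded ring carbon, gives no change at the digits printed from compound 2 to compound 3 (within the scatter). Within the data shown here, this is the first pair to isolate a change at this position, and it shows that, for this pair, the six-membered ring of piperidin-1-yl can give way to an amine with no ring while the number stays within the scatter. Nothing shown here accounts for this result.

Going by these compounds, it remains open whether a smaller amine such as dimethylamino, or a ring such as morpholin-4-yl, would also hold the number at this position. On these data alone, it is equally open whether the same tolerance would survive on a shorter or longer chain.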